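A few compounds are considered here, and "the series" means these few. Any claim that something is new, unique, unknown or untested is made for them only; others in the source may bear on it.

Compound 1, `NC1=NC2(CCCCC2)N(c2ccccc2)C(N)=N1`, and compound 2, `NC1=NC2(CCCCC2)N(c2ccc(Cl)cc2)C(N)=N1`, share one core, while compound 3, `Cc1nc(N)nc(Nc2cccc(Cl)c2)n1`, and compound 4, `Cc1nc(N)nc(Nc2ccc(Cl)c(Cl)c2)n1`, share another; the difference between the two cores is not broken down here. In an assay for inhibition of Dihydrofolate reductase (Bos taurus), using NADPH (a lower number here means a stronger inhibitor, a higher number a weaker inhibitor), compound 1 gives > 100000 nM, which is a limit of the assay rather than a number. Compound 2 likewise gives > 100000 nM, also a limit. In this assay compound 3 gives > 100000 nM, again a limit. Because all three values sit at the limit of > 100000 nM in this assay, at which 3 of the 3 values shown sit, the step that the two limits leave unreadable from compound 1 to compound 2, made by chloro in place of hydrogen on an aromatic carbon, cannot be sized. The change to compound 4 is the same kind of change, (chloro in place of hydrogen on an aromatic carbon), though the surroundings differ: here the entering group is ortho to a chloro group (1 heavy atom) and para to a group of 9 heavy atoms, whereas in compound 2 it is para to a large group. The step of a number no higher from compound 3 to compound 4 (the limit leaves the size open) is the one expected, resting only on the fact that compound 3 is reported as the limit > 100000 nM. Compound 4 is therefore expected to give about 100000 nM in this assay, with a range from 20000 nM to 300000 nM.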

Compound 4, half-maximal inhibitory concentration: > 100000 nM
Compound 4 was reported as a limit; the forecaster's own chance of this, stated with the estimate: 60%; the middle value lies on the limit itself.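

No size can be read for the step between compound 3 and compound 4, because both results in this assay are limits rather than numbers: the limit of > 100000 nM in this assay, at which 4 of the 4 values shown sit. The compounds shown leave open whether chloro in place of hydrogen on an aromatic carbon changes inhibition at all, and how strongly any of the four compounds inhibits.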